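Extending the Side Chain of a Lactam Analogue

The source may report more compounds than this note shows. Statements on the series, on what has been measured and on what is new or still open speak of the compounds shown alone.

Compound 1 `C/C(=N\CCCO)c1c(O)c2ccccc2oc1=O` carries an oxygen-containing core, and in an assay on isolated protein for inhibition of myosin-2 (Bos taurus), read by spectrophotometry, with a stated time of 24 min (on this read-out higher numbers stand for weaker inhibition and lower numbers for stronger inhibition), compound 1 gives 37000 nM. Compound 3 `C/C(=N\CCO)c1c(O)c2ccccc2oc1=O` shares that core, and in this assay compound 3 gives 92000 nM. Going by the values given here, the step of a 2.5-fold higher number from compound 1 to compound 3 (0.40 log units; beyond the scatter) is the only measured change in this set. Compound 2 `CCC/N=C(\C)c1c(O)c2ccccc2[nH]c1=O` has the lactam core with a propyl chain on the double-bonded nitrogen. In this assay compound 2 reaches only the limit of the assay, >= 100000 nM; this is a boundary, not a number, as the limit of >= 100000 nM in this assay, at which 1 of the 3 values shown sits, shows.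

Compound 4 `CCCCC/N=C(\C)c1c(O)c2ccccc2[nH]c1=O` differs from compound 2 by ethyl in place of hydrogen on a saturated chain carbon, three bonds along the chain from a double-bonded nitrogen, so that propyl becomes pentyl. Among the compounds with values here, no measured step concerns the lactam core or a change of this kind; the step from compound 1 to compound 3, which shortens a chain on the other core, was modest. Compound 4 is therefore expected to show at most a small step, an at least 1.2-fold lower number from compound 2 to compound 4 (0.09 log units; that floor lies within the scatter), and may again fall at the limit. The estimate for compound 4 in this assay is 80000 nM, with a range from 20000 nM to 250000 nM.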

Compound 4, half-maximal inhibitory concentration: >= 100000 nM
Compound 4 ended at the assay's limit; the forecaster's own chance of this, stated with the estimate: 50%; middle value at least 1.2-fold (0.09 log units) from the limit.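

In this assay compound 4 gives >= 100000 nM as a limit of the assay, not a number. Going by these compounds alone, compound 2 gives >= 100000 nM there, also a limit, so no step between compound 2 and compound 4 can be read. From the compounds shown here alone, how strongly either compound inhibits, and whether going from propyl to pentyl changes this at all, remains open.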